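Triazole substituent swap: cyclohexyl to phenyl

The source may report more compounds than this note shows. Statements on the series, on what has been measured and on what is new or still open speak of the compounds shown alone.

Three compounds sharing the core of compound 1 were measured in an assay on isolated protein for inhibition of Aromatase (Homo sapiens), read by fluorescence and colorimetric assay, with a stated time of 30 min; on this read-out lower numbers stand for stronger inhibition and higher numbers for weaker inhibition:
compound 1, `c1ccc(C(c2ccccc2)n2ccnn2)cc1`, 4580 nM
compound 2, `CCCc1cn(C(c2ccccc2)c2ccccc2)nn1`, 11000 nM
compound 3, `c1ccc(C(c2ccccc2)n2cc(C3CCCCC3)nn2)cc1`, 13700 nM

Compound 3 stands highest of the three numbers. Against compound 2 the gap is within the scatter (a 1.2-fold higher number from compound 2 to compound 3 (0.10 log units; within the scatter)), against compound 1 it is beyond it (a 3.0-fold higher number from compound 1 to compound 3 (0.48 log units; beyond the scatter)). Compound 4, `c1ccc(-c2cn(C(c3ccccc3)c3ccccc3)nn2)cc1`, differs from compound 3 by phenyl in place of cyclohexyl on an aromatic carbon. For the measured compounds named here, two steps bear on it: a 2.4-fold higher number from compound 1 to compound 2 (0.38 log units; beyond the scatter) and a 3.0-fold higher number from compound 1 to compound 3 (0.48 log units; beyond the scatter), both modest rises when a group occupies this carbon, while a 1.2-fold higher number from compound 2 to compound 3 (0.10 log units; within the scatter) shows propyl and cyclohexyl indistinguishable. Going by the values given here, no measured step exchanges a non-aromatic ring for an aromatic one at this place. A step within the scatter is therefore expected, a 1.2-fold lower number from compound 3 to compound 4 (0.10 log units; within the scatter). Compound 4 is estimated at 11000 nM, in the range 4000 nM to 30000 nM.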

Compound 4, half-maximal inhibitory concentration: 12900 nM
For compound 4 the middle estimate is 1.2-fold (0.07 log units) below the measured one, within the range that was stated.
By their numbers in this assay, from the lowest: compound 1; then compounds 2, 4 and 3 (each within the scatter of the next).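

Exchanging the non-aromatic ring for an aromatic one of the same size on this carbon gives no change that can be told apart (a 1.1-fold lower number from compound 3 to compound 4 (0.03 log units; within the scatter)), and phenyl is likewise not separated from propyl (a 1.2-fold higher number from compound 2 to compound 4 (0.07 log units; within the scatter)). Phenyl still carries the modest rise seen with the other two groups relative to hydrogen (a 2.8-fold higher number from compound 1 to compound 4 (0.45 log units; beyond the scatter)), so among these compounds, having a group on this carbon matters while its identity does not show. Nothing given here explains this result. On these data alone, whether an amine or a carboxylic acid on this carbon would follow the same pattern remains open.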